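This account rests on a few compounds, and the source may have more. Where it says the series, first, only, none or still open, it means among the compounds named here.

Three compounds have been measured in an ADME assay on RAW264.7 cells (Mus musculus) for cytotoxicity, read by MTT assay; on this read-out higher numbers stand for weaker inhibition and lower numbers for stronger inhibition:

Compound 1, `O=C(/C=C/C=C/c1ccccc1)c1ccccc1`: 44300 nM
Compound 2, `O=C(/C=C/C=C/c1ccccc1)c1cccc(O)c1`: 48700 nM
Compound 3, `O=C(/C=C/C=C/c1ccc(O)cc1)c1ccc(O)cc1`: > 100000 nM

Compound 1 and compound 2 share a core and differ in one place: hydroxy in place of hydrogen on an aromatic carbon. Across this change the reading in this assay moves by a 1.1-fold higher number from compound 1 to compound 2 (0.04 log units; within the scatter), so the two results cannot be told apart. For compound 3 this assay reports only a limit, > 100000 nM, which is not a number; the limit of > 100000 nM in this assay, at which 1 of the 3 values shown sits, is where this reading sits. How the core of compound 3 differs from the core of compound 1 is not broken down here.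

Compound 4, `O=C(/C=C/C=C/c1ccc(O)cc1O)c1ccc(O)cc1`, has not yet been measured in this assay. It differs from compound 3 in one place: hydroxy in place of hydrogen on an aromatic carbon. This is the same kind of change as that from compound 1 to compound 2, but the surroundings differ: in compound 2 the new hydroxy group sits meta to a large group, while in compound 4 it sits ortho to a large group and meta to a hydroxy group. Since the earlier change gave a 1.1-fold higher number from compound 1 to compound 2 (0.04 log units; within the scatter), a step of similar size is expected here: a number no higher from compound 3 to compound 4 (the limit leaves the size open). Because compound 3 already sits at the limit of > 100000 nM in this assay, at which 1 of the 3 values shown sits, the most likely outcome for compound 4 is expected to be another limit rather than a number. Compound 4 is therefore estimated at 100000 nM, with a range expected from 50000 nM to 250000 nM.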

Compound 4, half-maximal inhibitory concentration: > 100000 nM
Compound 4 gave a limit, no number (the forecaster's own chance of this, stated with the estimate: 65%); the middle value lies on the limit itself.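

In this assay, compound 3 and compound 4 each give a limit rather than a number, and the step from one to the other cannot be read: the limit of > 100000 nM in this assay, at which 2 of the 4 values shown sit. The compounds shown leave open whether hydroxy in place of hydrogen on an aromatic carbon changes the reading at all in compound 4, and how far beyond the limit compound 3 and compound 4 really lie.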